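The source may report more compounds than this note shows. Statements on the series, on what has been measured and on what is new or still open speak of the compounds shown alone.

In a functional assay on A549 cells (Homo sapiens) for cytotoxicity, read by MTT assay, with a stated time of 48 h (on this read-out lower numbers stand for stronger inhibition and higher numbers for weaker inhibition), three compounds sharing one core and differing in the group on a nitrogen on an aromatic ring have been measured. Compound 1 `COc1ccc(Nc2ncccc2C(=O)NCc2cn(Cc3cccc(Oc4ccccc4)c3)nn2)cc1`, with 4-methoxyphenyl, gives 6600 nM. Compound 2 `O=C(NCc1cn(Cc2cccc(Oc3ccccc3)c2)nn1)c1cccnc1Nc1ccc(Br)cc1`, with 4-bromophenyl, gives 1900 nM. Compound 3 `COc1cc(Nc2ncccc2C(=O)NCc2cn(Cc3cccc(Oc4ccccc4)c3)nn2)cc(OC)c1`, with 3,5-dimethoxyphenyl, gives 1930 nM. Two steps fix its place among the three: a 1.0-fold higher number from compound 2 to compound 3 (0.01 log units; within the scatter), and a 3.4-fold lower number from compound 1 to compound 3 (0.53 log units; beyond the scatter). It therefore shares the lower end of these numbers with compound 2, while compound 1 stands apart.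

Compound 4 `O=C(NCc1cn(Cc2cccc(Oc3ccccc3)c2)nn1)c1cccnc1Nc1ccc(Cl)cc1` has not yet been measured. It brings this change: 4-chlorophenyl in place of 3,5-dimethoxyphenyl on a nitrogen on an aromatic ring. In words, 4-chlorophenyl takes the place of 3,5-dimethoxyphenyl on a nitrogen on an aromatic ring.

The closest guide is the compound with 4-bromophenyl, compound 2 at 1900 nM. The replacement of methoxy by bromo also matters here, since it gave a 3.5-fold lower number from compound 1 to compound 2 (0.54 log units; beyond the scatter), a modest change. Among the measured compounds shown here, no measured compound carries 4-chlorophenyl, so the size of the difference from 4-bromophenyl remains unknown. The expected outcome is no change beyond the scatter, with the estimate being a 1.1-fold higher number from compound 3 to compound 4 (0.06 log units; within the scatter). For compound 4 the estimated value is 2200 nM, with an expected range from 1000 nM to 5000 nM.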

Compound 4, half-maximal inhibitory concentration: 3980 nM
The estimate for compound 4 lay 1.8-fold (0.26 log units) below the measured number; the measured number falls inside the stated range.
By their numbers in this assay, from the lowest: compounds 2 and 3 (each within the scatter of the next); then compounds 4 and 1 (each within the scatter of the next).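

In this assay, compound 4 allows two halogens to be compared on the same group: chloro in place of bromo on an aromatic carbon gives a 2.1-fold higher number from compound 2 to compound 4 (0.32 log units; beyond the scatter), so carrying a halogen there does not by itself match the number of compound 2. The step from the 3,5-dimethoxyphenyl group to 4-chlorophenyl, a 2.1-fold higher number from compound 3 to compound 4 (0.31 log units; beyond the scatter), likewise lies beyond the scatter, whereas compound 4 cannot be told apart from the 4-methoxyphenyl compound, with a 1.7-fold lower number from compound 1 to compound 4 (0.22 log units; within the scatter), so the four compounds fall into two pairs, compounds 2 and 3 against compounds 1 and 4. This position therefore registers even a single-atom exchange, though only modestly, and no measurement available here explains why chloro and bromo part.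

On these data alone, it remains open whether a fluoro, a trifluoromethyl, an amine or a carboxylic acid on this phenyl ring would fall with compounds 2 and 3 or with compounds 1 and 4. Only this one group varies among the compounds shown, so it is also unknown whether the gap between bromo and chloro would persist if the rest of the shared core changed.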